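The compounds below may be only part of what the source reports. "The series", "measured", "known", "first", "only" and "open" are said of these compounds alone.

Measured in a physicochemical assay for lipophilicity; on this read-out lower numbers stand for lower lipophilicity and higher numbers for higher lipophilicity
compound 1 `C=C1COOC2(CCC(Cc3ccc(F)cc3)CC2)OOC1` gives 4.2
compound 2 `C=C1COOC2(CCC(Cc3ccc(C(F)(F)F)cc3)CC2)OOC1` gives 4.95

Going by the values given here, compound 2, at 4.95 on this scale, holds the higher of the two numbers, and compound 1 is its only neighbour. The next structure is compound 3 `C=C1COOC2(CCC(Cc3ccc(C(=O)OC)cc3)CC2)OOC1`, and the change from compound 2 is methoxycarbonyl in place of trifluoromethyl on an aromatic carbon in a single place. In words, this is methoxycarbonyl in place of trifluoromethyl on an aromatic carbon, para to a large group.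

Among the compounds with values here, only one measured step bears on it, a number 0.75 log units higher from compound 1 to compound 2 (beyond the scatter) in this assay, which is modest but beyond the scatter and comes with trifluoromethyl in place of fluoro on an aromatic carbon. Within the data shown here, no measured compound carries methoxycarbonyl, so the data give no direct reading for that group, and the expectation below stays loose. With trifluoromethyl leaving, a fall of about the same size as that one step is expected, which would bring the number back near that of compound 1 at 4.2 in this assay. The estimated change is a number 0.85 log units lower from compound 2 to compound 3 (beyond the scatter) and it is expected to lie beyond the scatter. For compound 3 the estimate is 4.1 with an expected range from 3.7 to 4.5 on this scale.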

Compound 3, partition coefficient: 4.05
The estimate for compound 3 lay 0.05 log units above the measured number; measured number inside the range.
By their numbers in this assay, from the lowest: compounds 3 and 1 (each within the scatter of the next); then compound 2.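

In this assay, methoxycarbonyl in place of trifluoromethyl on an aromatic carbon, para to a large group, gives a number 0.90 log units lower from compound 2 to compound 3 (beyond the scatter) even though both groups have 4 heavy atoms, so the heavy-atom count does not by itself set the number at this place. Against fluoro at the same place, the reading is a number 0.15 log units lower from compound 1 to compound 3 (within the scatter) and the two groups cannot be told apart on this read-out, which leaves trifluoromethyl as the only one of the three groups whose compound stands clear of the other two. The result also adds a group with 2 hydrogen-bond acceptors to the comparison, yet no information on the origin of these steps is available.

Going by these compounds, it remains open whether an amine, a carboxylic acid or a primary amide on this aromatic carbon would stay within the scatter of compound 1 and compound 3 or move clear of them. Also open, on these data alone, is whether an ester with a longer chain in place of methoxycarbonyl would stay with these two compounds or come closer to compound 2.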